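2-chlorobenzyl to 4-methylbenzyl, with only limits so far

The source may report more compounds than this note shows. Statements on the series, on what has been measured and on what is new or still open speak of the compounds shown alone.

Compound 1 `O=C(O)c1ccc(C(=O)/C(=C\c2ccc(F)c([N+](=O)[O-])c2)SCc2ccc(Cl)cc2Cl)cc1`: < 1000 ug/mL (a limit)
Compound 2 `O=C(O)c1ccc(C(=O)/C(=C\c2ccc(F)c([N+](=O)[O-])c2)SCc2ccccc2Cl)cc1`: < 1000 ug/mL (a limit)

Both entries come from a physicochemical assay for solubility; on this read-out lower numbers stand for lower solubility and higher numbers for higher solubility. In this assay compound 2 gives < 1000 ug/mL, which is a limit and not a number. It shares that position with compound 1, and the whole picture so far is the limit of < 1000 ug/mL in this assay, at which 2 of the 2 values shown sit.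

Compound 3 `Cc1ccc(CS/C(=C/c2ccc(F)c([N+](=O)[O-])c2)C(=O)c2ccc(C(=O)O)cc2)cc1` keeps the rest of compound 2 and alters one group: 4-methylphenyl in place of 2-chlorophenyl on a saturated chain carbon bound to a sulfur. Put simply, 4-methylphenyl stands in place of 2-chlorophenyl on a saturated chain carbon bound to a sulfur.

For the measured compounds named here, only one measured step bears on this change: a step that the two limits leave unreadable from compound 1 to compound 2. It is hydrogen in place of chloro on an aromatic carbon, and it offers neither a size nor a direction to carry over. In this assay, then, no step beyond the usual scatter is expected, in either direction, and the expected step is a step that the limit leaves unreadable from compound 2 to compound 3. A report as a limit is the likeliest outcome. For compound 3 the estimated value is 500 ug/mL, with an expected range of 100 ug/mL to 1000 ug/mL.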

Compound 3, solubility: < 1000 ug/mL
Compound 3: a limit, no number; the forecaster's own chance of this, stated with the estimate: 85%; the middle value is on the limit's open side.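

Neither new step can be read: the steps from compound 2 to compound 3 and from compound 1 to compound 3 join two limits, not two numbers. Compound 1, compound 2 and compound 3 share one position in this assay: the limit of < 1000 ug/mL in this assay, at which 3 of the 3 values shown sit.

The compounds shown leave open how their solubilities compare, and whether 4-methylbenzyl in place of 2-chlorobenzyl makes any difference.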